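Iodothiophene Replaces Dichlorothiophene in a Vero Cytotoxicity Series

This account rests on a few compounds, and the source may have more. Where it says the series, first, only, none or still open, it means among the compounds named here.

Compound 1 `Cc1ccsc1C1=NNC(c2ccc(N3CCCCC3)cc2)C1` carries a 3-methylthiophen-2-yl group on the carbon with a double bond to nitrogen of the shared core, and in an ADME assay on Vero cells (Chlorocebus sabaeus) for cytotoxicity, with a stated time of 5 days (on this read-out higher numbers stand for weaker inhibition and lower numbers for stronger inhibition), compound 1 gives 11400 nM. Compound 2 `Clc1ccc(C2=NNC(c3ccc(N4CCCCC4)cc3)C2)s1` bears a 5-chlorothiophen-2-yl group instead; for compound 2 this assay reports only a limit, > 100000 nM. Compound 3 `Clc1cc(C2=NNC(c3ccc(N4CCCCC4)cc3)C2)c(Cl)s1` has a 2,5-dichlorothiophen-3-yl group and in this assay compound 3 gives 53900 nM. Among the two numbers compound 3 stands highest, and the nearest number belongs to compound 1: a 4.7-fold higher number from compound 1 to compound 3 (0.67 log units; beyond the scatter). The halogen-bearing thiophenes therefore both sit well above the methyl analogue on this read-out.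

Compound 4 `Ic1ccc(C2=NNC(c3ccc(N4CCCCC4)cc3)C2)s1` is the next member: 5-iodothiophen-2-yl in place of 2,5-dichlorothiophen-3-yl on a carbon with a double bond to nitrogen. Within the data shown here, two measured steps bear on it. First, an at least 8.7-fold higher number from compound 1 to compound 2 (0.94 log units; beyond the scatter), which shows that a 5-halothiophen-2-yl group can push the number to the limit of the assay. Second, an at least 1.8-fold lower number from compound 2 to compound 3 (0.26 log units; that floor lies within the scatter), so the two halogenated patterns are not separated beyond the scatter. Compound 4 shares the 5-halothiophen-2-yl arrangement of compound 2, and on that basis compound 4 is expected to move toward the limit, with a step of a 1.9-fold higher number from compound 3 to compound 4 (0.27 log units; within the scatter). Compound 4 is thus estimated at 100000 nM, within a range of 40000 nM to 300000 nM.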

Compound 4, half-maximal inhibitory concentration: 15900 nM
Compound 4: middle estimate off by 6.3-fold (0.80 log units), on the high side, outside the stated range (below it).
By their numbers in this assay, from the lowest: compounds 1 and 4 (each within the scatter of the next); then compound 3. At a limit, above all of these: compound 2.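

Iodo in place of chloro on an aromatic carbon gives an at least 6.2-fold lower number from compound 2 to compound 4 (0.79 log units; beyond the scatter) so the 5-halothiophen-2-yl arrangement alone does not hold the number at the limit, and the identity of the halogen at this place can move it. For compound 2 the entry in this assay is a limit and not a number, so that step can be read only as a floor: the limit of > 100000 nM in this assay, at which 1 of the 4 values shown sits. The 5-iodothiophen-2-yl group in place of 2,5-dichlorothiophen-3-yl gives a 3.4-fold lower number from compound 3 to compound 4 (0.53 log units; beyond the scatter) while in place of 3-methylthiophen-2-yl it gives a 1.4-fold higher number from compound 1 to compound 4 (0.14 log units; within the scatter) so a halogen on the thiophene does not by itself set the number well above the methyl analogue, a pattern that compounds 2 and 3 follow and compound 4 goes against.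

The compounds shown leave open how a bromo or a methyl group in place of the iodo would read at this place, and whether the number follows the halogen in any ordered way. They also leave open whether an amine or a carboxylic acid on the thiophene would move the number, and how large the gap to compound 2 really is.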